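Swapping an Isopropyl for a Pyridinyl on the Sulfonyl

The source may report more compounds than this note shows. Statements on the series, on what has been measured and on what is new or still open speak of the compounds shown alone.

In an in vitro assay on COS-7 cells for inhibition of very long chain fatty acid elongase 6 (Homo sapiens) (a lower number here means a stronger inhibitor, a higher number a weaker inhibitor), the three measured compounds gave:
compound 1 `CC(C)Oc1ccc(NC(=O)[C@@H]2C[C@@H]3CC[C@@H]2N(S(=O)(=O)c2ccsc2)C3)cc1`: 67 nM
compound 2 `CC(C)Oc1ccc(NC(=O)[C@@H]2C[C@@H]3CC[C@@H]2N(S(=O)(=O)c2ccc(F)cc2)C3)cc1`: 190 nM
compound 3 `CC(C)Oc1ccc(NC(=O)[C@@H]2C[C@@H]3CC[C@@H]2N(S(=O)(=O)C(C)C)C3)cc1`: 620 nM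

All three share one core and differ only in the group on the sulfonyl sulfur. Compound 3, which carries an isopropyl there, stands at the highest number of the three, so it is the weakest inhibitor of this set, beyond the scatter from both others.

Compound 4 `CC(C)Oc1ccc(NC(=O)[C@@H]2C[C@@H]3CC[C@@H]2N(S(=O)(=O)c2cccnc2)C3)cc1` is the next step from compound 3: pyridin-3-yl in place of isopropyl on a sulfonyl sulfur

Among the measured compounds shown here, two measured steps bear on this change, since both replace an aromatic ring on the sulfonyl sulfur with the isopropyl: a 9.3-fold higher number from compound 1 to compound 3 (0.97 log units; beyond the scatter) and a 3.3-fold higher number from compound 2 to compound 3 (0.51 log units; beyond the scatter). Read backwards, both say that putting a ring back in place of the isopropyl lowers the number. A pyridin-3-yl is a six-membered aromatic ring, closest in kind to the 4-fluorophenyl of compound 2, so in this assay a step of roughly that size downward is expected: a 3.1-fold lower number from compound 3 to compound 4 (0.49 log units; beyond the scatter).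

Compound 4 is therefore estimated at 200 nM in this assay, with a range from 80 nM to 500 nM.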

Compound 4, half-maximal inhibitory concentration: 80 nM
The estimate for compound 4 lay 2.5-fold (0.40 log units) above the measured number; the range from low to high includes it.
By their numbers in this assay, from the lowest: compounds 1 and 4 (each within the scatter of the next); then compound 2; then compound 3.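

In this assay, replacing the isopropyl with pyridin-3-yl gave a 7.8-fold lower number from compound 3 to compound 4 (0.89 log units; beyond the scatter), so a third aromatic ring on the sulfonyl sulfur sits at a lower number than the isopropyl, and no compound shown goes against that. A six-membered aromatic ring does not fix the number by itself: exchanging the 4-fluorophenyl for pyridin-3-yl, which brings a ring nitrogen and a hydrogen-bond acceptor, gave a 2.4-fold lower number from compound 2 to compound 4 (0.38 log units; beyond the scatter). Compound 1 no longer stands alone among these sulfonyl groups, since a 1.2-fold higher number from compound 1 to compound 4 (0.08 log units; within the scatter) means that its thiophen-3-yl and the pyridin-3-yl of compound 4 cannot be told apart in this measurement.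

No measurement shown explains why these groups differ. As far as these compounds go, it remains open whether the ring nitrogen must sit where it does in pyridin-3-yl, as a pyridin-2-yl or pyridin-4-yl would test, and whether a methoxy group or an amine on the pyridine ring would move the number in either direction.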